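Replacing a Hydroxy Group with Bromo on a Shared Core

The source may hold more compounds than are shown below. What is called first, only, known or untested is meant among the compounds shown, and "the series" means these compounds.

Of the compounds shown here, three built on one shared core have been measured so far. Compound 1 `COc1ccccc1/C=C(/SCc1ccc(C)cc1)C(=O)c1ccc(Cl)cc1`, compound 2 `O=C(/C(=C\c1ccc(O)cc1)S(=O)(=O)Cc1ccc(F)cc1)c1ccc(Br)cc1` and compound 3 `Cc1ccc(/C=C(/SCc2ccc(Cl)cc2)C(=O)c2ccc(Cl)cc2)s1` were each tested in a functional assay on DU-145 cells (Homo sapiens) for inhibition, read by trypan blue exclusion, with a stated time of 96 h; a lower number here means a stronger inhibitor of growth, a higher number a weaker inhibitor of growth. In this assay compound 1 gives 10000 nM. In this assay compound 2 gives 10000 nM, level with compound 1 at the digits shown, so the two sit together as the lowest numbers of the three. In this assay compound 3 gives 50000 nM, a higher number than compound 2 by a margin beyond the scatter.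

The next compound, compound 4 `O=C(/C(=C\c1ccc(Br)cc1)S(=O)(=O)Cc1ccc(F)cc1)c1ccc(Br)cc1`, differs from compound 2 in a single place:

bromo in place of hydroxy on an aromatic carbon

Going by the values given here, no measured pair differs by this same exchange, so there is no earlier step to set a direction. The step expected in this assay is no change at the digits printed from compound 2 to compound 4 (within the scatter), which amounts to none beyond the scatter. Compound 4 is therefore expected to give about 10000 nM in this assay, with a range from 4000 nM to 30000 nM.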

Compound 4, concentration for 50% growth inhibition: 25000 nM
For compound 4 the middle estimate is 2.5-fold (0.40 log units) below the measured one; low and high end bracket the measured number.
By their numbers in this assay, from the lowest: compounds 1 and 2 (each within the scatter of the next); then compounds 4 and 3 (each within the scatter of the next).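

Going by these compounds alone, the 4-hydroxyphenyl to 4-bromophenyl exchange gives the first step that can be read across a single change. In this assay, bromo in place of hydroxy brings a 2.5-fold higher number from compound 2 to compound 4 (0.40 log units; beyond the scatter), so at this position the hydroxy compound is the stronger inhibitor of growth, though the step is only modest. This shows that the group at this position can shift the growth read-out beyond the usual scatter, but nothing at hand says what lies behind the shift.

On these data alone, whether an amine or a carboxylic acid at this position would give a lower or a higher number stays open. One exchange on one core also leaves open whether bromo in place of hydroxy would give a step of the same direction and size on the cores of compound 1 and compound 3.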